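Aryl substituent change in the arylpiperazine amide series

A few compounds are considered here, and "the series" means these few. Any claim that something is new, unique, unknown or untested is made for them only; others in the source may bear on it.

Three compounds have numbers in a functional assay on aorta for antagonist activity at Alpha-1D adrenergic receptor (Rattus norvegicus); on this read-out higher numbers stand for weaker binding and lower numbers for tighter binding. Compound 1 `COc1ccccc1N1CCN(CCCNc2ccncc2C(=O)N(C(C)C)C(C)C)CC1` gives 251 nM. Compound 2 `COc1ccccc1N1CCN(CCCNc2ccc(C(=O)N(C)C)cn2)CC1` gives 31.6 nM. Compound 3 `CN(C)C(=O)c1cccnc1NCCCN1CCN(c2ccccc2C#N)CC1` gives 10 nM, the lowest of the three numbers: the gap to compound 2 is the nearest and lies beyond the scatter, and the gap to compound 1 is the widest and also lies beyond the scatter. Going by the values given here, no two measured compounds differ in only one place, so no single structural step has been measured within this set.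

Compound 4 `CN(C)C(=O)c1cccnc1NCCCN1CCN(c2ccccc2C(F)(F)F)CC1` is not yet measured. It differs from compound 3 in one place: trifluoromethyl in place of cyano on an aromatic carbon. Nothing in the measured set shows what trifluoromethyl in place of cyano does on this aromatic carbon, so the expectation rests on compound 3 alone. The step from compound 3 to compound 4 in this assay is expected to be small, with a slightly higher number more likely than a lower one, estimated as a 2.0-fold higher number from compound 3 to compound 4 (0.30 log units; within the scatter). Compound 4 is accordingly estimated at 20 nM in this assay, with a range from 6 nM to 63 nM; a result within the scatter of compound 3 would not be surprising.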

Compound 4, dissociation constant: 316 nM
Estimate against measurement, compound 4: 16-fold (1.20 log units) below; measured number outside the range, above it.
By their numbers in this assay, from the lowest: compound 3; then compound 2; then compounds 1 and 4 (each within the scatter of the next).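

In this assay, going by these compounds alone, the change from 2-cyanophenyl to 2-(trifluoromethyl)phenyl gives a 32-fold higher number from compound 3 to compound 4 (1.50 log units; beyond the scatter), the first step that can be read at a single place. With the rest of compound 3 held fixed, the read-out is therefore highly sensitive to the group on this aromatic carbon, ortho to a large group, and here cyano gives the far lower number, so the two groups cannot be treated as interchangeable at this position. Nothing at hand speaks to the origin of this step.

As far as these compounds go, it remains open whether a chlorine atom, a methyl group or a plain hydrogen on this carbon would give a number closer to that of compound 3 or to that of compound 4, which would show whether the step reflects something particular to cyano or to trifluoromethyl. Also open, from the compounds shown here alone, is whether the same change keeps its size on the core of compound 1 or of compound 2, where the amide differs, or with a longer chain in place of the propyl linker.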